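Swapping a methoxyethyl for an oxolane ring on a triazole

The source may hold more compounds than are shown below. What is called first, only, known or untested is meant among the compounds shown, and "the series" means these compounds.

Measured so far:
Compound 1, `CCCCCn1nc(C(=O)N[C@H]2COc3ccccc3N(C)C2=S)nc1Cc1ccccc1`: in a toxicity assay on HT-29 cells (Homo sapiens) for cytotoxicity (a lower number here means that less compound is tolerated, a higher number that more compound is tolerated), compound 1 gives > 100000 nM, a limit of the assay.
Compound 2, `CC(C)Cn1nc(C(=O)N[C@H]2COc3ccccc3N(C)C2=S)nc1Cc1ccccc1`: in this assay compound 2 gives > 100000 nM, also a limit.
Compound 3, `COCCn1nc(C(=O)N[C@H]2COc3ccccc3N(C)C2=S)nc1Cc1ccccc1`: in this assay compound 3 gives > 100000 nM, again a limit.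

All three compounds share one core and differ only in the group on the aromatic nitrogen of the five-membered ring. None of them reached a readable number: the limit of > 100000 nM in this assay, at which 3 of the 3 values shown sit. The steps a step that the two limits leave unreadable from compound 1 to compound 2, a step that the two limits leave unreadable from compound 1 to compound 3 and a step that the two limits leave unreadable from compound 2 to compound 3 cannot be sized. Compound 3 stands at the same limit as the other two.

Compound 4, `CN1C(=S)[C@@H](NC(=O)c2nc(Cc3ccccc3)n(C3CCOC3)n2)COc2ccccc21`, carries the change (oxolan-3-yl in place of 2-methoxyethyl on an aromatic nitrogen). The change is of the same kind as the three measured steps, each a swap of the substituent on that aromatic nitrogen, and each of those left the tolerated concentration at the limit. Within the data shown here, since no measured step gives a readable size, the expected step of a number no higher from compound 3 to compound 4 (the limit leaves the size open) is estimated to stay within the scatter, with the value most likely again reported as a limit. Compound 4 is therefore expected to give 100000 nM, with a range from 50000 nM to 300000 nM.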

Compound 4, half-maximal cytotoxic concentration: > 100000 nM
Compound 4 was reported as a limit; the forecaster's own chance of this, stated with the estimate: 85%; the middle value lies on the limit itself.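

No new step can be read, since compound 4, like compound 1, compound 2 and compound 3, gives only a limit in this assay: the limit of > 100000 nM in this assay, at which 4 of the 4 values shown sit.

The compounds shown leave open at what concentration each of the four becomes toxic to these cells, and whether the group on the aromatic nitrogen affects that concentration at all.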